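The compounds below may be only part of what the source reports. "The series", "measured", "known", "first", "only" and "open" are said of these compounds alone.

Compound 1 `O=c1ccoc2cc(OCc3cn(Cc4ccccc4)nn3)ccc12` gives > 300000 nM in an ADME assay on L02 cells (Homo sapiens) for cytotoxicity, read by MTT assay, with a stated time of 48 h (on this read-out higher numbers stand for weaker inhibition and lower numbers for stronger inhibition), a limit of the assay rather than a number.
Compound 2 `O=c1ccoc2cc(OCc3cn(Cc4ccc(Cl)cc4)nn3)ccc12` gives > 300000 nM in this assay, again a limit.
Compound 3 `O=c1ccoc2cc(OCc3cn(Cc4ccc(F)cc4)nn3)ccc12` gives > 300000 nM in this assay, also a limit.

Compound 3 therefore stands at the same ceiling as the other two, (the limit of > 300000 nM in this assay, at which 3 of the 3 values shown sit). Compound 4 `CC(C)(C)c1ccc(Cn2cc(COc3ccc4c(=O)ccoc4c3)nn2)cc1` differs from compound 3 by tert-butyl in place of fluoro on an aromatic carbon. Among the compounds with values here, the only steps measured so far are a step that the two limits leave unreadable from compound 1 to compound 2, a step that the two limits leave unreadable from compound 1 to compound 3 and a step that the two limits leave unreadable from compound 2 to compound 3; none of them can be sized, and none involves a tert-butyl group. Compound 4 is therefore expected to stay at the ceiling as well, with an estimated 300000 nM (range 80000 nM to 600000 nM). This corresponds to an expected step of a number no higher from compound 3 to compound 4 (the limit leaves the size open), most likely reported only as a limit.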

Compound 4, half-maximal inhibitory concentration: > 300000 nM
Compound 4 gave a limit, no number; the forecaster's own chance of this, stated with the estimate: 75%; the middle value sits exactly at the limit.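

Within the data shown here, compound 4 also gives only a limit, so no step to it from compound 1, compound 2 or compound 3 can be read: the limit of > 300000 nM in this assay, at which 4 of the 4 values shown sit. The compounds shown leave open whether their true values differ at all.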